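Replacing an arylamino hydrazide by a diacylhydrazine

The compounds below may be only part of what the source reports. "The series", "measured", "known", "first", "only" and "open" are said of these compounds alone.

Compound 1 `Cc1cccc(NNC(=O)c2cccc(NS(=O)(=O)c3cnc(O)nc3O)c2)c1` is one of three related sulfonamides examined in a functional assay on OVCAR-3 cells (Homo sapiens) for antiproliferative activity, read by MTT assay, with a stated time of 24 h; a lower number here means a stronger inhibitor, a higher number a weaker inhibitor. Compound 1 gives only a limit in this assay, > 20000 nM. Compound 2 `Cc1cccc(NNC(=O)c2ccccc2NS(=O)(=O)c2cnc(O)nc2O)c1` likewise gives only a limit, > 20000 nM. Compound 3 `O=C(NNC(=O)c1cccc(Cl)c1)c1ccc(NS(=O)(=O)c2cnc(O)nc2O)cc1`, which carries a (3-chlorophenyl)carbonyl group on the hydrazide, gives a numerical value of 7710 nM in this assay. Thus compound 1 sits at the weak end of the set: the limit of > 20000 nM in this assay, at which 2 of the 3 values shown sit.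

Compound 4 `O=C(NNC(=O)c1cccc(NS(=O)(=O)c2cnc(O)nc2O)c1)c1cccc(Cl)c1` differs from compound 1 in one place: (3-chlorophenyl)carbonyl in place of 3-methylphenyl on an amine nitrogen. Among the measured compounds shown here, no measured pair shows this exact change, so the size of the step is uncertain. For the measured compounds named here, because compound 3, the only member with a (3-chlorophenyl)carbonyl group, reaches 7710 nM, a modest gain for compound 4 is expected, though the gain may not exceed the scatter. The step from compound 1 to compound 4 is estimated at an at least 1.8-fold lower number from compound 1 to compound 4 (0.25 log units; that floor lies within the scatter). Compound 4 is expected to give about 11000 nM in this assay, within a range from 4000 nM to 30000 nM.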

Compound 4, half-maximal inhibitory concentration: 13500 nM
Compound 4: the middle estimate sits 1.2-fold (0.09 log units) below what was measured; the range from low to high includes it.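

Among the compounds shown here, putting (3-chlorophenyl)carbonyl in place of 3-methylphenyl on this amine nitrogen, whose other neighbour is an amide-type nitrogen, moves the read-out from a limit to a number, something the earlier compounds could not show for this position. In this assay the change gives an at least 1.4-fold lower number from compound 1 to compound 4 (0.17 log units; that floor lies within the scatter), which is a floor and not a size, and it does not establish a gain beyond the usual scatter. Compound 1 gives only a limit, so the true size of the step cannot be fixed: the limit of > 20000 nM in this assay, at which 2 of the 4 values shown sit.

Whether the carbonyl or the chlorine accounts for the step remains open. Also open, from the compounds shown here alone, is how this amine nitrogen would respond to an unsubstituted benzoyl group, an acetyl group or a longer alkyl chain.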